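The source may hold more compounds than are shown below. What is called first, only, known or untested is meant among the compounds shown, and "the series" means these compounds.

Measured so far:

Compound 1, `CCCCc1nc(=O)c(S(=O)(=O)c2ccc(-c3ccnc(NC(=O)C4CC4)c3)cc2)c(O)n1-c1c(OC)cccc1OC`: 72%
Compound 2, `CCCCc1nc(=O)c(S(=O)(=O)c2ccc(-c3ccc(F)cc3)cc2)c(O)n1-c1c(OC)cccc1OC`: 5%
Compound 3, `CCCCc1nc(=O)c(S(=O)(=O)c2ccc(-c3ccc(F)nc3)cc2)c(O)n1-c1c(OC)cccc1OC`: 2%

In an ADME assay on microsomes from liver (Rattus norvegicus) for metabolic stability, using NADPH, with a stated time of 10 min (a lower number here means that less of the compound is left, a higher number that more of the compound is left), compound 3 gives 2%, the lowest of the three numbers. Its nearest neighbour is compound 2, and the step of a number 3 percentage points lower from compound 2 to compound 3 (within the scatter) lies within the scatter, so the two cannot be told apart. Its furthest neighbour is compound 1, and the step of a number 70 percentage points lower from compound 1 to compound 3 (beyond the scatter) is large; likewise the step of a number 67 percentage points lower from compound 1 to compound 2 (beyond the scatter) is large.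

Compound 4, `CCCCc1nc(=O)c(S(=O)(=O)c2ccc(-n3cc(Cl)ccc3=O)cc2)c(O)n1-c1c(OC)cccc1OC`, differs from compound 3 at one place: a group of 8 heavy atoms (5 carbon, 1 nitrogen, 1 oxygen, 1 chlorine; one six-membered aromatic ring with 1 hetero atom) in place of a group of 7 heavy atoms (5 carbon, 1 nitrogen, 1 fluorine; one six-membered aromatic ring with 1 hetero atom), on an aromatic carbon

Which measured steps bear on this change? The step of a number 3 percentage points lower from compound 2 to compound 3 (within the scatter) shows that swapping one six-membered ring for another with one hetero atom changed nothing beyond the scatter, and both compounds 2 and 3 sit low. The large steps from compound 1 involve a group carrying an amide, which the entering group does not have. Among the compounds with values here, no measured step covers the entering group itself, so the expectation in this assay rests on the low values of compounds 2 and 3, with wide uncertainty. Compound 4 is expected to give about 15%, ranging from 2% to 55%. The estimated step of a number 13 percentage points higher from compound 3 to compound 4 (beyond the scatter) is expected to stay within or just beyond the scatter, upward if at all.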

Compound 4, percent of the compound remaining: 74%
Compound 4: the middle estimate sits 59 percentage points below what was measured; measured number above the stated range.
By their numbers in this assay, from the lowest: compounds 3 and 2 (each within the scatter of the next); then compounds 1 and 4 (each within the scatter of the next).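

In this assay, the position para to a large group does not depend on the amide of compound 1 for a high number: the step of a number 72 percentage points higher from compound 3 to compound 4 (beyond the scatter) and the step of a number 69 percentage points higher from compound 2 to compound 4 (beyond the scatter) are both large, although the entering group of 8 heavy atoms carries no amide. The step of a number 2 percentage points higher from compound 1 to compound 4 (within the scatter) shows that this group and 2-((cyclopropylcarbonyl)amino)pyridin-4-yl cannot be told apart here, whereas 4-fluorophenyl and 6-fluoropyridin-3-yl stay low in compound 2 and compound 3. Nothing measured here explains this difference between the groups.

The compounds shown do not separate the contribution of the chlorine from that of the ring carbonyl. Going by these compounds, whether a methyl or methoxy group in place of the chlorine would keep the number high also remains open.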